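The source may report more compounds than this note shows. Statements on the series, on what has been measured and on what is new or still open speak of the compounds shown alone.

Measured so far:
compound 1 `CCN(CC)S(=O)(=O)c1ccc(S(=O)(=O)N2CCC[C@@H](C(=O)N[C@@H]3CCN(C(=O)OC(C)(C)C)C3)C2)cc1` — 400 nM
compound 2 `CCOC(=O)C1CCN(S(=O)(=O)c2ccc(S(=O)(=O)N(CC)CC)cc2)CC1` — 23100 nM
compound 3 `CCOC(=O)[C@@H]1CCCN(S(=O)(=O)c2ccc(S(=O)(=O)N(CC)CC)c(F)c2)C1` — 1600 nM

Of the compounds shown here, three have been tested in a functional assay on BXPC-3 cells (Homo sapiens) for inhibition, read by MTT assay, with a stated time of 7 days; a higher number here means a weaker inhibitor, a lower number a stronger inhibitor. Compound 1 gives the lowest number of the three, at 400 nM. Its nearest neighbour on the numbers is compound 3, whose value of 1600 nM lies beyond the scatter from compound 1; compound 2, at 23100 nM, stands furthest away, also well beyond the scatter. No pair among these three differs in one place only, so the numbers are compared as they stand, without a counted step between them.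

Compound 4 `CCN(CC)S(=O)(=O)c1ccc(S(=O)(=O)N2CCC[C@@H](C(=O)NC3COC3)C2)cc1` has not yet been measured in this assay. It differs from compound 1 in one place: oxetan-3-yl in place of 1-(tert-butoxycarbonyl)pyrrolidin-3-yl on an amide-type nitrogen. A large, substituted group leaves and a small ring takes its place on an amide-type nitrogen, while the shared core of compound 1 is kept.

Among the compounds with values here, no measured step covers a change of this kind. The two compounds without an amide side chain, compound 2 and compound 3, give the higher numbers, which suggests that what hangs from that position matters, and a much smaller group is expected to cost something. The step from compound 1 to compound 4 is expected to be a 3.8-fold higher number from compound 1 to compound 4 (0.57 log units; beyond the scatter), towards a higher number in this assay. Compound 4 is accordingly estimated at 1500 nM, with a range from 400 nM to 6000 nM.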

Compound 4, half-maximal inhibitory concentration: 13800 nM
Compound 4: the middle estimate sits 9.2-fold (0.96 log units) below what was measured, outside the stated range (above it).
By their numbers in this assay, from the lowest: compound 1; then compound 3; then compounds 4 and 2 (each within the scatter of the next).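

In this assay, putting oxetan-3-yl in place of 1-(tert-butoxycarbonyl)pyrrolidin-3-yl on the amide-type nitrogen gives a 35-fold higher number from compound 1 to compound 4 (1.54 log units; beyond the scatter), the first measured sign that the group at this position can by itself shift the number by a large step while the shared core stays the same. The group that leaves has 12 heavy atoms and the group that enters has 4, and they also differ in ring size and in the double bond outside aromatic rings, so this single step cannot show which of these differences accounts for the change. Nothing measured here gives a reason for the size of this step.

As far as these compounds go, it remains open how a free pyrrolidin-3-yl amine, a cyclopentyl ring or a longer alkyl chain on the same nitrogen would read, and so whether the tert-butoxycarbonyl part, the five-membered ring or size alone sets the number. From the compounds shown here alone, it is equally open whether the defined stereocentre of the group that leaves plays any part in the step.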